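Removing a Piperazine Tail From a Longer Side Chain

A few compounds are considered here, and "the series" means these few. Any claim that something is new, unique, unknown or untested is made for them only; others in the source may bear on it.

Measured so far:
compound 1 `CN1CCN(CCn2c(N)c(-c3nc4ccccc4[nH]3)c3nc(C#N)c(C#N)nc32)CC1` gives 9110 nM
compound 2 `CCCn1c(N)c(-c2nc3ccccc3[nH]2)c2nc(C#N)c(C#N)nc21` gives > 50000 nM
compound 3 `CN1CCN(CCCn2c(N)c(-c3nc4ccccc4[nH]3)c3nc(C#N)c(C#N)nc32)CC1` gives 4520 nM

All three were tested in a functional assay on cells (Homo sapiens) for antiproliferative activity, read by MTT assay, with a stated time of 48 h; a higher number here means a weaker inhibitor, a lower number a stronger inhibitor. The value of compound 2 is a limit of the assay, not a number, (the limit of > 50000 nM in this assay, at which 1 of the 3 values shown sits). Compound 1 and compound 3 share the same kind of side chain, and the cores differ only by (4-methylpiperazin-1-yl)methyl in place of 4-methylpiperazin-1-yl on a saturated chain carbon, two bonds along the chain from an aromatic nitrogen; the step is a 2.0-fold lower number from compound 1 to compound 3 (0.30 log units; within the scatter).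

Compound 4 `CCCCn1c(N)c(-c2nc3ccccc3[nH]2)c2nc(C#N)c(C#N)nc21` is not yet measured. It is made from compound 3 by methyl in place of 4-methylpiperazin-1-yl on a saturated chain carbon, three bonds along the chain from an aromatic nitrogen. The same kind of change has already been made from compound 1 to compound 2, namely (methyl in place of 4-methylpiperazin-1-yl on a saturated chain carbon, two bonds along the chain from an aromatic nitrogen), with the place two bonds rather than three bonds along the chain from the aromatic nitrogen. That step was an at least 5.4-fold higher number from compound 1 to compound 2 (0.73 log units; beyond the scatter). Because the step from compound 2 to compound 3 was an at least 11-fold lower number from compound 2 to compound 3 (1.04 log units; beyond the scatter), the tail appears to matter on either chain length. For compound 4 a similar loss is expected, a 13-fold higher number from compound 3 to compound 4 (1.12 log units; beyond the scatter), most likely ending at the assay limit. The estimate for compound 4 is 60000 nM.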

Compound 4, half-maximal inhibitory concentration: > 50000 nM
Compound 4 ended at the assay's limit; the forecaster's own chance of this, stated with the estimate: 70%; the middle value is on the limit's open side.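

In this assay compound 4 gives > 50000 nM, which is a limit of the assay and not a number. Replacing the 4-methylpiperazin-1-yl tail with methyl at the chain end gives an at least 11-fold higher number from compound 3 to compound 4 (1.04 log units; beyond the scatter), and the simple butyl chain also compares poorly with the shorter tailed chain, with an at least 5.4-fold higher number from compound 1 to compound 4 (0.73 log units; beyond the scatter). The loss therefore carries over in direction from one chain length to the other, but not demonstrably in size: the same change on two cores in this assay, an at least 5.4-fold higher number (0.73 log units; beyond the scatter) from compound 1 to compound 2 and an at least 11-fold higher number (1.04 log units; beyond the scatter) from compound 3 to compound 4; the limit leaves it open whether they differ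

Going by these compounds, the step between compound 2 and compound 4 cannot be read, and the true strength of both remains hidden: the limit of > 50000 nM in this assay, at which 2 of the 4 values shown sit. It also remains open whether another amine, such as morpholine or dimethylamine, or a longer chain carrying the tail would keep the activity.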